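Swapping the amine on the thiocarbonyl: compound 3

The compounds below may be only part of what the source reports. "The series", "measured", "known", "first", "only" and "open" are said of these compounds alone.

Compound 1, `CCOC(=O)c1cc(=O)c2cc(CSC(=S)N(C)c3ccccc3)ccc2o1`, in a functional assay on HeLa cells (Homo sapiens) for antiproliferative activity, read by MTT assay, with a stated time of 72 h (a higher number here means a weaker inhibitor, a lower number a stronger inhibitor), gives 18100 nM.
Compound 2, `CCOC(=O)c1cc(=O)c2cc(CSC(=S)N(C(C)C)C(C)C)ccc2o1`, in this assay gives only a limit of the assay, > 25000 nM.

Compound 2 thus stands at the limit of this assay, as the limit of > 25000 nM in this assay, at which 1 of the 2 values shown sits, records. Compound 3, `CCOC(=O)c1cc(=O)c2cc(CSC(=S)N3CCCC3)ccc2o1`, differs from it by pyrrolidin-1-yl in place of diisopropylamino on a thiocarbonyl carbon. Among the measured compounds shown here, the one measured step, an at least 1.3-fold higher number from compound 1 to compound 2 (0.14 log units; that floor lies within the scatter), also exchanged the group on the thiocarbonyl carbon and lay within the scatter, so no step beyond the scatter is expected here either, a number no higher from compound 2 to compound 3 (the limit leaves the size open). Compound 3 is accordingly estimated at 25000 nM, with a range from 9000 nM to 60000 nM.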

Compound 3, half-maximal inhibitory concentration: 6600 nM
Beside the measured number, compound 3's estimate is 3.8-fold (0.58 log units) above it, and the stated range ends above it.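

The earlier pair showed no step beyond the scatter, but here the amine on the thiocarbonyl carbon clearly matters. In this assay, pyrrolidin-1-yl gives an at least 3.7-fold lower number from compound 2 to compound 3 (0.57 log units; beyond the scatter) and also a 2.7-fold lower number from compound 1 to compound 3 (0.44 log units; beyond the scatter), making compound 3 the strongest of the three. The first step is only a floor, as compound 2 carries a limit and not a number: the limit of > 25000 nM in this assay, at which 1 of the 3 values shown sits.

Pyrrolidin-1-yl is the only ring amine shown here. From the compounds shown here alone, whether the ring itself counts stays open, and piperidin-1-yl, morpholin-4-yl or open-chain diethylamino on the same carbon could test it.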